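The compounds below may be only part of what the source reports. "The series", "measured", "known", "first", "only" and "open" are said of these compounds alone.

Measured compounds:
- compound 1, `O=C(NCc1ccc(S(=O)(=O)c2ccccc2)cc1)c1cc2ccncc2s1`: 7 nM
- compound 2, `O=C(NCc1ccc(S(=O)(=O)N2CCCCC2)cc1)c1ccc2nc[nH]c2c1`: 310 nM
- compound 3, `O=C(NCc1ccc(S(=O)(=O)c2cccc(C(F)(F)F)c2)cc1)c1cc2ccncc2s1`: 3 nM

In an assay for inhibition of Nicotinamide phosphoribosyltransferase (Homo sapiens), read by mass spectrometry, with stated times of 15 min and 30 min (a higher number here means a weaker inhibitor, a lower number a stronger inhibitor), compound 1 gives 7 nM and stands second highest of the three numbers. Its nearest neighbour is compound 3, which differs only by a trifluoromethyl in place of hydrogen on an aromatic carbon; that step, a 2.3-fold lower number from compound 1 to compound 3 (0.37 log units; beyond the scatter), is modest but beyond the scatter. Compound 2 is furthest away: it differs from compound 1 in more than one place, and its value in this assay is far higher than that of compound 1.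

Compound 4, `O=C(NCc1ccc(S(=O)(=O)c2ccccc2)cc1)c1cnc2nccn2c1`, is not yet measured. It differs from compound 1 on a carbonyl carbon whose other neighbour is an amide-type nitrogen: a group of 9 heavy atoms (6 carbon, 3 nitrogen; one five-membered aromatic ring with 2 hetero atoms, one six-membered aromatic ring with 2 hetero atoms) in place of a group of 9 heavy atoms (7 carbon, 1 nitrogen, 1 sulfur; one five-membered aromatic ring with 1 hetero atom, one six-membered aromatic ring with 1 hetero atom), on a carbonyl carbon

Among the compounds with values here, none of the measured steps touches this part of the molecule. The step from compound 1 to compound 3 concerns the group attached to the sulfone and says nothing about the group on the carbonyl carbon. Compound 2 carries yet another group there, but because it also changes the sulfonyl part, its value cannot be read as a step. The direction and size of the change for compound 4 are therefore uncertain, and the estimate is held wide. Compound 4 is expected to give about 30 nM in this assay, within a range of 5 nM to 200 nM, which would mean an expected step of a 4.3-fold higher number from compound 1 to compound 4 (0.63 log units; beyond the scatter).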

Compound 4, half-maximal inhibitory concentration: 2 nM
The estimate for compound 4 lay 15-fold (1.18 log units) above the measured number; measured number below the stated range.
By their numbers in this assay, from the lowest: compounds 4 and 3 (each within the scatter of the next); then compound 1; then compound 2.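

Within the data shown here, this is the first readable step at the group on the carbonyl carbon: in this assay, exchanging the group of 7 carbon, 1 nitrogen and 1 sulfur for the group of 6 carbon and 3 nitrogen gives a 3.5-fold lower number from compound 1 to compound 4 (0.54 log units; beyond the scatter). The group on the carbonyl carbon therefore need not contain sulfur for a low number in this assay, and a group with 3 hydrogen-bond acceptors in place of 2 serves there at least as well, with the heavy-atom count and the pair of five-membered and six-membered aromatic rings unchanged. Why the number falls cannot be said, since nothing shown here speaks to the cause of this step.

The compounds shown leave open whether this exchange would move the number in the same direction and by a similar amount on the trifluoromethyl-bearing compound 3, where the change would fall on a different background. They also leave open how the number would respond to a methyl, a methoxy group or an amine carried on the entering group.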